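Methoxyphenyl Analogue in a Pentacyclic Cytotoxic Series

The source may hold more compounds than are shown below. What is called first, only, known or untested is meant among the compounds shown, and "the series" means these compounds.

Measured compounds:
Compound 1 `Cc1nc2c3ccccc3ccc2c2nc3c(ccc4ccccc43)c(-c3ccccc3S)c12`: 1420 nM
Compound 2 `Cc1ccc(-c2c3ccc4ccccc4c3nc3c2c(C)nc2c4ccccc4ccc32)cc1`: 67000 nM
Compound 3 `Cc1nc2c3ccccc3ccc2c2nc3c(ccc4ccccc43)c(-c3cccc([N+](=O)[O-])c3)c12`: 13200 nM

In a functional assay on HCT-116 cells (Homo sapiens) for cytotoxicity, read by MTT assay, with a stated time of 48 h (on this read-out lower numbers stand for stronger inhibition and higher numbers for weaker inhibition), compound 3 stands second highest of the three numbers, nearest to compound 2 and furthest from compound 1. The step of a 5.1-fold lower number from compound 2 to compound 3 (0.71 log units; beyond the scatter) separates it from compound 2, and the step of a 9.3-fold higher number from compound 1 to compound 3 (0.97 log units; beyond the scatter) from compound 1; the remaining step is a 47-fold higher number from compound 1 to compound 2 (1.67 log units; beyond the scatter).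

Compound 4 `COc1ccc(-c2c3ccc4ccccc4c3nc3c2c(C)nc2c4ccccc4ccc32)cc1` has not been measured. The change from compound 3 is 4-methoxyphenyl in place of 3-nitrophenyl on an aromatic carbon.

The step that bears most directly on this change is a 5.1-fold lower number from compound 2 to compound 3 (0.71 log units; beyond the scatter), since compound 2 also carries a group on the same position with a substituent in the 4-position; read in reverse, it points to a higher number. The step of a 9.3-fold higher number from compound 1 to compound 3 (0.97 log units; beyond the scatter) shows that the 3-nitrophenyl group itself already gives a weaker result than the 2-sulfanylphenyl group. A modest step upward, beyond the scatter, is therefore expected in this assay, with compound 4 likely landing between compound 3 and compound 2.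

Compound 4 is estimated to give 40000 nM, within a range of 10000 nM to 120000 nM, which is expected to correspond to the step of a 3.0-fold higher number from compound 3 to compound 4 (0.48 log units; beyond the scatter).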

Compound 4, half-maximal inhibitory concentration: > 80000 nM
Compound 4: only a limit was reported (the forecaster's own chance of this, stated with the estimate: 10%); middle value at least 2.0-fold (0.30 log units) away from the limit.
By their numbers in this assay, from the lowest: compound 1; then compound 3; then compound 2. At a limit, above all of these: compound 4.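

In this assay compound 4 gives > 80000 nM, which is a limit of the assay and not a number: the limit of > 80000 nM in this assay, at which 1 of the 4 values shown sits. Even so, the change on the aromatic carbon opposite the ring nitrogen can be read against two of the other groups, with an at least 6.0-fold higher number from compound 3 to compound 4 (0.78 log units; beyond the scatter) and an at least 56-fold higher number from compound 1 to compound 4 (1.75 log units; beyond the scatter), so 4-methoxyphenyl gives no gain over 3-nitrophenyl or 2-sulfanylphenyl. Against 4-methylphenyl the reading is an at least 1.1-fold higher number from compound 2 to compound 4 (0.07 log units; that floor lies within the scatter), so methoxy and methyl cannot be told apart here, and the two groups with a substituent in the 4-position both stand at the high end of the series.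

From the compounds shown here alone, how far compound 4 lies beyond its limit remains open. Also open, going by these compounds, is whether an amine or a carboxylic acid on this phenyl ring would bring the number closer to that of compound 1.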